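The compounds below may be only part of what the source reports. "The series", "measured", "known", "first", "only" and "open" are said of these compounds alone.

Compound 1 `CN(C)c1ccc(-c2nc3c(N4CCN(CC(=O)Nc5cccnc5)CC4)c(Br)cnc3[nH]2)cc1` was tested in a functional assay on HCT-116 cells (Homo sapiens) for inhibition, read by MTT assay, with a stated time of 72 h (a lower number here means a stronger inhibitor of growth, a higher number a weaker inhibitor of growth), and gave 1650 nM. Compound 2 `CN(C)c1ccc(-c2nc3c(N4CCN(S(=O)(=O)c5ccccc5)CC4)c(Br)cnc3[nH]2)cc1` has only "not determined" (no result reported) in this assay, so it stands nowhere on the numbers; the only measured point in this set is compound 1. Compound 3 `CC(c1ccncc1)N1CCN(c2c(Br)cnc3[nH]c(-c4ccc(N(C)C)cc4)nc23)CC1` is still to be measured. It differs from compound 2 in one place on an amine nitrogen in a ring of a six-membered non-aromatic ring with 2 nitrogen: 1-(pyridin-4-yl)ethyl in place of phenylsulfonyl on an amine nitrogen in a ring. Among the measured compounds shown here, no step between two measured compounds is known here, so there is nothing to say how large a shift in this assay this exchange brings, or in which direction. For the measured compounds named here, the single measured value, that of compound 1 at 1650 nM, gives only a rough level for the series. Compound 3 is therefore expected to give about 1200 nM in this assay, with a range from 250 nM to 6000 nM.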

Compound 3, concentration for 50% growth inhibition: 900 nM
Compound 3: middle estimate off by 1.3-fold (0.12 log units), on the high side; measured number inside the range.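

In this assay, the amine nitrogen in the six-membered ring now has two groups with a measured result, and the step gives a 1.8-fold lower number from compound 1 to compound 3 (0.26 log units; within the scatter) with 1-(pyridin-4-yl)ethyl in place of ((pyridin-3-yl)carbamoyl)methyl, so this assay does not separate these two groups. The exchange of phenylsulfonyl for 1-(pyridin-4-yl)ethyl cannot be read, since compound 2 has no number to compare with compound 3. Nothing measured here bears on why these two groups give results within the scatter of each other.

The compounds shown leave open whether a plain benzyl group, a phenyl ring in place of the pyridine, or a 1-(pyridin-3-yl)ethyl group on the same nitrogen would fall at the same level. They also leave open whether removing the methyl branch of 1-(pyridin-4-yl)ethyl, or leaving only a hydrogen on that nitrogen, would shift the result.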